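Swapping Nitro for Methyl: Compound 4 Awaits Measurement

The source may report more compounds than this note shows. Statements on the series, on what has been measured and on what is new or still open speak of the compounds shown alone.

Three compounds have been measured in a functional assay on SSMC-7721 cells (Homo sapiens) for antiproliferative activity, read by CCK-8 assay, with a stated time of 48 h; a higher number here means a weaker inhibitor, a lower number a stronger inhibitor:

Compound 1 `O=c1c2ccccc2[se]n1-c1nnc(-c2cccc([N+](=O)[O-])c2)s1` — 27300 nM
Compound 2 `O=c1c2ccccc2[se]n1-c1nnc(-c2ccccc2[N+](=O)[O-])s1` — 22500 nM
Compound 3 `COc1cc(-c2nnc(-n3[se]c4ccccc4c3=O)s2)cc(OC)c1OC` — 7150 nM

Compound 2 stands second highest of the three numbers. Its nearest neighbour is compound 1, whose number lies higher only within the scatter, so no order can be read between them; compound 3 gives a lower number, a gap beyond the scatter. Compound 4 `Cc1ccccc1-c1nnc(-n2[se]c3ccccc3c2=O)s1` is not yet measured. It differs from compound 2 by methyl in place of nitro on an aromatic carbon. Within the data shown here, no pair of measured compounds shows this exchange, so its size is not known directly. The estimated step of a 1.6-fold lower number from compound 2 to compound 4 (0.21 log units; within the scatter) is expected to be modest, toward a lower number, barely beyond the scatter. Compound 4 is therefore expected to give about 14000 nM, between 5000 nM and 40000 nM.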

Compound 4, half-maximal inhibitory concentration: 19400 nM
Compound 4: the middle estimate sits 1.4-fold (0.14 log units) below what was measured, and the stated range covers the measured number.
By their numbers in this assay, from the lowest: compound 3; then compounds 4, 2 and 1 (each within the scatter of the next).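

In this assay, exchanging nitro for methyl on this aromatic carbon, ortho to a large group, gives a 1.2-fold lower number from compound 2 to compound 4 (0.06 log units; within the scatter) and so shows no change that can be read. At this position, the two hydrogen-bond acceptors of nitro are therefore not required to keep the number within the scatter of compound 2. No measured evidence here explains this result. On these data alone, whether an amine or a carboxylic acid on this carbon would shift the number remains open. So does whether methyl would behave the same way elsewhere on this ring.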